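Pyridin-2-yl replacing furan-3-yl on the shared core

The compounds below may be only part of what the source reports. "The series", "measured", "known", "first", "only" and "open" are said of these compounds alone.

Compound 2 `Oc1ccc(-c2cc(-c3ccoc3)cc(-c3cccc(O)c3)n2)cc1` gives 930 nM in a functional assay on HCT-15 cells (Homo sapiens) for cytotoxicity, read by CCK-8 assay (on this read-out higher numbers stand for weaker inhibition and lower numbers for stronger inhibition), and stands lowest of the two numbers, with compound 1 `Oc1ccc(-c2cc(-c3ccsc3)cc(-c3cccc(O)c3)n2)cc1` nearest at 1180 nM. For the measured compounds named here, the only measured step, a 1.3-fold lower number from compound 1 to compound 2 (0.10 log units; within the scatter), lies within the scatter. Compound 3 `Oc1ccc(-c2cc(-c3ccccn3)cc(-c3cccc(O)c3)n2)cc1` differs from compound 2 by pyridin-2-yl in place of furan-3-yl on an aromatic carbon. Going by the values given here, this is again an exchange of one heteroaryl group at the same aromatic carbon, and the one comparable exchange moved this assay only within the scatter, so no step beyond the scatter is expected. Compound 3 is estimated at 1000 nM, with a range from 400 nM to 2500 nM. The expected step is thus a 1.1-fold higher number from compound 2 to compound 3 (0.03 log units; within the scatter).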

Compound 3, half-maximal inhibitory concentration: > 50000 nM
Compound 3 ended at the assay's limit; the forecaster's own chance of this, stated with the estimate: 2%; middle value at least 50-fold (1.69 log units) away from the limit.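

Unlike the exchange between the two five-membered rings, pyridin-2-yl at this aromatic carbon gives an at least 53-fold higher number from compound 2 to compound 3 (1.73 log units; beyond the scatter) and an at least 42-fold higher number from compound 1 to compound 3 (1.62 log units; beyond the scatter). The position therefore does not accept every heteroaryl group alike in this assay. Compound 3 stands at a limit of the assay and not at a number: the limit of > 50000 nM in this assay, at which 1 of the 3 values shown sits.

The change swaps a five-membered ring for a six-membered one and an oxygen or sulfur for a ring nitrogen, and the compounds shown do not separate these. Going by these compounds, whether phenyl, pyridin-3-yl or pyridin-4-yl at this carbon would stay near compound 2 remains open.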